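Chalcone Amide and Neuroblastoma Cell Viability

The source may report more compounds than this note shows. Statements on the series, on what has been measured and on what is new or still open speak of the compounds shown alone.

The series rests on a shared core that is kept throughout. Compound 1 `CCCNC(=O)c1ccc(/C=C/C(=O)c2ccc(OC)cc2O)cc1` carries a propylcarbamoyl group. In an ADME assay on SH-SY5Y cells (Homo sapiens) for cytotoxicity, read by MTT assay, with a stated time of 48 h (on this read-out lower numbers stand for stronger inhibition and higher numbers for weaker inhibition), compound 1 gives > 100000 nM, a limit of the assay rather than a number. Compound 2 `COc1ccc(C(=O)/C=C/c2ccc(C(=O)O)cc2)c(O)c1` carries a carboxy group in that position. In this assay compound 2 gives > 100000 nM, which is again a limit. Compound 3 `COc1ccc(C(=O)/C=C/c2ccc(OCc3ccccc3)cc2)c(O)c1` carries a benzyloxy group there. In this assay compound 3 gives > 100000 nM, also a limit. Thus compound 2 stands where every measured member stands, at the limit of > 100000 nM in this assay, at which 3 of the 3 values shown sit. The three measured steps, a step that the two limits leave unreadable from compound 1 to compound 2, a step that the two limits leave unreadable from compound 1 to compound 3 and a step that the two limits leave unreadable from compound 2 to compound 3, therefore carry no readable size. The step from compound 1 to compound 2 touches the same carbonyl carbon that is altered in the new compound, yet its size is unreadable.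

Compound 4 `COc1ccc(C(=O)/C=C/c2ccc(C(=O)Nc3ccc(C)cc3C)cc2)c(O)c1` differs from compound 2 by (2,4-dimethylphenyl)amino in place of hydroxy on a carbonyl carbon. Within the data shown here, with no measured step giving a direction, the step from compound 2 to compound 4 in this assay is expected to be a step that the limit leaves unreadable from compound 2 to compound 4, none beyond the scatter. Compound 4 in this assay is therefore expected near 120000 nM, within 30000 nM to 400000 nM, most likely reported again as a limit.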

Compound 4, half-maximal inhibitory concentration: > 100000 nM
Compound 4 ended at the assay's limit; the forecaster's own chance of this, stated with the estimate: 70%; the middle value lies beyond the limit too.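

In this assay compound 4 gives > 100000 nM as a limit of the assay and not a number. Its steps from compound 1 and from compound 2 therefore cannot be read, and all four compounds share one result: the limit of > 100000 nM in this assay, at which 4 of the 4 values shown sit. The compounds shown leave open whether any change on the shared core would give a measurable value in this assay at all.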